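A few compounds are considered here, and "the series" means these few. Any claim that something is new, unique, unknown or untested is made for them only; others in the source may bear on it.

Compound 1 `Cc1ccc(-c2nn(-c3ccccc3)cc2-c2nc3ccccc3[nH]2)cc1`: 4950 nM
Compound 2 `FC(F)(F)c1ccc(-c2nn(-c3ccccc3)cc2-c2nc3ccccc3[nH]2)cc1`: 4670 nM
Compound 3 `Cc1ccc(-c2nn(-c3ccccc3)cc2-c2nc3ccccc3n2S(=O)(=O)c2cc(C)ccc2C)cc1`: 370 nM

These values come from a functional assay on HeLa cells (Homo sapiens) for antiproliferative activity, read by MTT assay, with a stated time of 24 h (on this read-out higher numbers stand for weaker inhibition and lower numbers for stronger inhibition), where compound 3 has the lowest number of the three and is the most potent. Compound 4 `Cc1ccc(-c2nn(-c3ccccc3)cc2-c2nc3ccccc3n2S(=O)(=O)c2ccc(C(F)(F)F)cc2)cc1` differs from compound 3 only in the group on the sulfonyl sulfur: 4-(trifluoromethyl)phenyl in place of 2,5-dimethylphenyl on a sulfonyl sulfur. Among the compounds with values here, two measured steps bear on this. Adding the sulfonyl group gave a 13-fold lower number from compound 1 to compound 3 (1.13 log units; beyond the scatter), and compound 4 keeps that sulfonyl. Replacing methyl with trifluoromethyl elsewhere in the molecule gave only a 1.1-fold lower number from compound 1 to compound 2 (0.03 log units; within the scatter). Neither step tests this exact swap, so no change beyond the scatter is expected. The expected step is a 1.2-fold higher number from compound 3 to compound 4 (0.09 log units; within the scatter). Compound 4 is estimated at 450 nM, with an expected range of 150 nM to 1400 nM.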

Compound 4, half-maximal inhibitory concentration: 1520 nM
The estimate for compound 4 lay 3.4-fold (0.53 log units) below the measured number, outside the stated range (above it).
By their numbers in this assay, from the lowest: compound 3; then compound 4; then compounds 2 and 1 (each within the scatter of the next).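

In this assay, the group on the sulfonyl sulfur proves to matter: 4-(trifluoromethyl)phenyl in place of 2,5-dimethylphenyl gives a 4.1-fold higher number from compound 3 to compound 4 (0.61 log units; beyond the scatter). The potency of compound 3 therefore cannot be credited to the sulfonyl alone, since what the sulfur carries also shifts the result. No measurement at hand explains this shift.

The swap removes two methyl groups and adds a trifluoromethyl at once, and the compounds shown do not separate these changes. From the compounds shown here alone, how an amine, a carboxylic acid or a simple methyl on the sulfonyl sulfur would behave also remains open.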